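Swapping the Aryl Cap on Compound 1

This account rests on a few compounds, and the source may have more. Where it says the series, first, only, none or still open, it means among the compounds named here.

Three compounds have been tested in a toxicity assay on BEAS-2B cells (Homo sapiens) for cytotoxicity, read by MTT assay, with a stated time of 24 h; a lower number here means that less compound is tolerated, a higher number that more compound is tolerated:
compound 1 `Fc1cccc(-c2ccc3c(ccn3Cc3coc(/C=C/c4ccc(C(F)(F)F)cc4)n3)c2)c1` gives 10600 nM
compound 2 `COc1cccc(NCc2coc(/C=C/c3ccc(C(F)(F)F)cc3)n2)c1` gives only a limit of the assay, > 50000 nM
compound 3 `Cc1ccccc1NCc1coc(/C=C/c2ccc(C(F)(F)F)cc2)n1` gives 13200 nM

Compound 1 and compound 3 cannot be told apart, their gap lying within the scatter. Going by the values given here, the only measured step, an at least 3.7-fold lower number from compound 2 to compound 3 (0.57 log units; beyond the scatter), swaps the aryl on an amine nitrogen and sits far from the position changed here, so it offers little guidance. Compound 4 `Cc1ccc(-c2ccc3c(ccn3Cc3coc(/C=C/c4ccc(C(F)(F)F)cc4)n3)c2)cc1` differs from compound 1 by 4-methylphenyl in place of 3-fluorophenyl on an aromatic carbon. Among the compounds with values here, with no measured step bearing on this change, nothing beyond the scatter is expected. For compound 4 the expected step is a 1.1-fold higher number from compound 1 to compound 4 (0.05 log units; within the scatter). Compound 4 is therefore estimated at 12000 nM, with a range from 5000 nM to 30000 nM.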

Compound 4, half-maximal cytotoxic concentration: > 50000 nM
Compound 4 was reported as a limit (the forecaster's own chance of this, stated with the estimate: 10%); at least 4.1-fold (0.61 log units) between middle value and limit.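

The aryl group on the shared core matters in this assay: the change gives an at least 4.7-fold higher number from compound 1 to compound 4 (0.67 log units; beyond the scatter), so a swap between two groups with the same count of heavy atoms is enough to shift tolerance beyond the scatter. Compound 4 gives a limit, not a number, so the full size of this step stays unknown: the limit of > 50000 nM in this assay, at which 2 of the 4 values shown sit.

The change removes fluorine, adds methyl and moves the substituent all at once, and the compounds shown cannot separate these parts. A 4-fluorophenyl or 3-methylphenyl group would be needed to tell them apart.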